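The source may hold more compounds than are shown below. What is called first, only, known or untested is meant among the compounds shown, and "the series" means these compounds.

The measured compounds:
Compound 1 `O=C(NC(=S)NNc1ncnc2ccccc12)c1ccc(C(F)(F)F)cc1` gives 8050 nM in a functional assay on MCF7 cells (Homo sapiens) for cytotoxicity, read by MTT assay, with a stated time of 72 h; a lower number here means a stronger inhibitor, a higher number a weaker inhibitor.
Compound 2 `COc1cc2ncnc(NNC(=S)NC(=O)c3ccc(F)cc3)c2cc1OC` gives 25800 nM in this assay.
Compound 3 `COc1cc2ncnc(NNC(=S)NC(=O)c3ccccc3Cl)c2cc1OC` gives 23100 nM in this assay.

Compound 1 has the lowest number of the three, and its gaps to compound 3 and to compound 2 are both beyond the scatter, so it is the strongest inhibitor of this small set. Compound 4 `O=C(NC(=S)NNc1ncnc2ccccc12)c1ccccc1` differs from compound 1 in one place: hydrogen in place of trifluoromethyl on an aromatic carbon. For the measured compounds named here, the only measured step, a 1.1-fold lower number from compound 2 to compound 3 (0.05 log units; within the scatter), exchanges one substituted phenyl for another on a carbonyl carbon in compounds whose core differs from that of compound 1, and it stayed within the scatter. Going by the values given here, it does not test the removal of a trifluoromethyl group, so no measured step bears directly on the change to compound 4. With nothing to point firmly either way, only a mild move toward a weaker inhibitor is expected, since compound 1 with its trifluoromethyl group is the strongest of the set. The expected step is a 1.5-fold higher number from compound 1 to compound 4 (0.17 log units; within the scatter). Compound 4 is therefore estimated at 12000 nM, with a likely range from 5000 nM to 30000 nM.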

Compound 4, half-maximal inhibitory concentration: 5960 nM
Compound 4: the middle estimate sits 2.0-fold (0.30 log units) above what was measured; measured number inside the range.
By their numbers in this assay, from the lowest: compounds 4 and 1 (each within the scatter of the next); then compounds 3 and 2 (each within the scatter of the next).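

In this assay, replacing the trifluoromethyl group on this aromatic carbon with hydrogen gives a 1.4-fold lower number from compound 1 to compound 4 (0.13 log units; within the scatter), so on the core of compound 1 the two compounds cannot be told apart. For the compounds shown here, the earlier compounds could not show this, as their only measured step swapped one substituted phenyl for another on a different core, whereas here a group of 4 heavy atoms is removed altogether and the number stays within the usual spread of repeat measurements; the trifluoromethyl group is therefore not required for the activity seen in compound 1. Nothing measured here offers an explanation for the two compounds reading alike.

This single exchange says nothing about how other groups at this place would behave, and an amine, a carboxylic acid or a longer chain such as butyl might move the number well beyond that spread, or might not. It also leaves open whether removing a group from this place would be as uneventful on the core shared by compound 2 and compound 3, which carries two methoxy groups.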